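Series notes: aryl group change from compound 3 to compound 4

The compounds below may be only part of what the source reports. "The series", "measured", "known", "first", "only" and "open" are said of these compounds alone.

Of the compounds shown here, three on a shared core have been measured in a functional assay on HCT-116 cells (Homo sapiens) for inhibition, read by sulforhodamine B assay, with a stated time of 48 h, tested at 10 uM; on this read-out higher numbers stand for more inhibition at the one concentration tested (going by the name of the read-out) and lower numbers for less inhibition. Compound 1 `c1ccc(-c2cn3ccnc3c(-c3ccc4ncn(C5CCCCC5)c4c3)n2)cc1` gives 59.5%. Compound 2 `c1ccc2c(-c3cn4ccnc4c(-c4ccc5ncn(C6CCCCC6)c5c4)n3)cccc2c1` gives 17.9% in this assay. Compound 3 `Clc1ccc(-c2cn3ccnc3c(-c3ccc4ncn(C5CCCCC5)c4c3)n2)cc1` gives 7.34% in this assay, the lowest of the three numbers; its nearest neighbour is compound 2 and the furthest is compound 1. All three measured steps run downward: a number 41.6 percentage points lower from compound 1 to compound 2 (beyond the scatter), a number 52.2 percentage points lower from compound 1 to compound 3 (beyond the scatter) and a number 10.6 percentage points lower from compound 2 to compound 3 (beyond the scatter).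

Compound 4 `Fc1ccccc1-c1cn2ccnc2c(-c2ccc3ncn(C4CCCCC4)c3c2)n1` differs from compound 3 by 2-fluorophenyl in place of 4-chlorophenyl on an aromatic carbon. Within the data shown here, no measured step involves a 2-fluorophenyl group, so the bearing of the measured steps is indirect. The step of a number 52.2 percentage points lower from compound 1 to compound 3 (beyond the scatter) shows that placing chloro on the phenyl of compound 1 removed most of the inhibition, and a number 41.6 percentage points lower from compound 1 to compound 2 (beyond the scatter) shows a large drop for the larger naphthalen-1-yl as well; the unsubstituted phenyl of compound 1 remains the highest value. Among the measured compounds shown here, compound 4 removes the chloro but brings in fluoro, so the step is expected to be upward from compound 3, of moderate size, a number 22.7 percentage points higher from compound 3 to compound 4 (beyond the scatter), though with wide uncertainty since no fluoro analogue has been measured. Compound 4 is therefore estimated at 30% in this assay, within a range from 8% to 58%.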

Compound 4, a percentage reported as inhibition, at one concentration (the size of the read-out at that concentration, not a potency): 25.8%
The estimate for compound 4 lay 4.2 percentage points above the measured number; low and high end bracket the measured number.
By their numbers in this assay, from the lowest: compound 3; then compounds 2 and 4 (each within the scatter of the next); then compound 1.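

At this position of the shared core, the halogen-bearing phenyl groups do not behave alike in this assay: 2-fluorophenyl retains more inhibition than 4-chlorophenyl (a number 18.5 percentage points higher from compound 3 to compound 4 (beyond the scatter)), so a halogen on this phenyl does not by itself bring the number down to the level of compound 3. Even so, the fluoro group does not restore the level of the unsubstituted phenyl (a number 33.7 percentage points lower from compound 1 to compound 4 (beyond the scatter)), which leaves compound 1 above all three other compounds, while 2-fluorophenyl and naphthalen-1-yl cannot be told apart (a number 7.9 percentage points higher from compound 2 to compound 4 (within the scatter)). No measurement in hand accounts for these differences.

The change from compound 3 to compound 4 alters both the halogen and its place on the phenyl, so the compounds shown cannot separate the contribution of one from that of the other. Also open, on these data alone, is whether a phenyl carrying a group other than a halogen, such as an amine or a carboxylic acid, could match or exceed compound 1 at this position.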